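Solubility notes: the step from compound 3 to compound 4

A few compounds are considered here, and "the series" means these few. Any claim that something is new, unique, unknown or untested is made for them only; others in the source may bear on it.

Measured so far:
compound 1 `COC(=O)C1=C(C)NC(c2nccs2)=NC1(C)c1ccc(OC)cc1`: 106 ug/mL
compound 2 `COC(=O)C1=C(C)NC(c2nccs2)=NC1(C)c1ccc(C#N)cc1`: 87 ug/mL
compound 3 `COC(=O)C1=C(CN2CC3CC2CO3)NC(c2nccs2)=NC1(C)c1ccc(F)cc1`: 564 ug/mL

In a physicochemical assay for solubility, read by HPLC, in phosphate buffer, at pH 6.5 (a lower number here means a less soluble compound, a higher number a more soluble compound), compound 3 stands highest of the three, beyond the scatter from both compound 1 and compound 2. Compound 4 `COC(=O)C1=C(COC2CCOC2)NC(c2nccs2)=NC1(C)c1ccc(F)cc1` differs from it in one place: a group of 6 heavy atoms (4 carbon, 2 oxygen; one five-membered non-aromatic ring with 1 hetero atom) in place of a group of 7 heavy atoms (5 carbon, 1 nitrogen, 1 oxygen; 2 five-membered non-aromatic rings with 1 hetero atom each), on a saturated chain carbon bound to a double-bonded ring carbon. For the measured compounds named here, the only measured step, a 1.2-fold lower number from compound 1 to compound 2 (0.09 log units; within the scatter), concerns the aromatic ring, not the saturated chain carbon, and lies within the scatter, so no measured step bears directly on this change. The two compounds without the leaving group, compound 1 at 106 ug/mL and compound 2 at 87 ug/mL, sit well below compound 3. A downward step a 3.5-fold lower number from compound 3 to compound 4 (0.55 log units; beyond the scatter) is therefore expected. Compound 4 is estimated at 160 ug/mL, with a range from 50 ug/mL to 450 ug/mL.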

Compound 4, solubility: 30 ug/mL
Compound 4: the middle estimate sits 5.3-fold (0.73 log units) above what was measured, outside the stated range (below it).
By their numbers in this assay, from the lowest: compound 4; then compounds 2 and 1 (each within the scatter of the next); then compound 3.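

In this assay the saturated chain carbon bound to a double-bonded ring carbon is not indifferent to what it carries: (oxolan-3-yl)oxy in place of the nitrogen-bearing group of 7 heavy atoms gives a 19-fold lower number from compound 3 to compound 4 (1.27 log units; beyond the scatter) in this pair. Both groups count 0 hydrogen-bond donors, 2 hydrogen-bond acceptors and no net charge, so these counts do not separate them. Nothing measured on these compounds accounts for the size of the step.

Open, going by these compounds, is whether the nitrogen or the rest of the group carries the difference. A simple amine such as dimethylamino, or a morpholine, on the same carbon would bear on that.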